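Extending the Hydroxamate Chain on Two Related Cores

This account rests on a few compounds, and the source may have more. Where it says the series, first, only, none or still open, it means among the compounds named here.

Compound 1 `Nc1ncnc2c1c(-c1cnc3[nH]ccc3c1)nn2CCCCC(=O)NO`, a functional assay on A549 cells (Homo sapiens) for inhibition, read by MTT assay, with a stated time of 72 h; a lower number here means a stronger inhibitor, a higher number a weaker inhibitor: > 150000 nM.
Compound 2 `Nc1nc2cc(-c3nn(CCC(=O)NO)c4ncnc(N)c34)ccc2o1`, this assay: > 150000 nM.
Compound 3 `Nc1ncnc2c1c(-c1cnc3[nH]ccc3c1)nn2CCCCCCC(=O)NO`, this assay: 50000 nM.

The value of compound 1 is a limit of this assay, not a number. The value of compound 2 is likewise a limit (the limit of > 150000 nM in this assay, at which 2 of the 3 values shown sit). Compound 3 alone gives a number, and the step of an at least 3.0-fold lower number from compound 1 to compound 3 (0.47 log units; beyond the scatter) comes from the change (2-(hydroxycarbamoyl)ethyl in place of hydroxycarbamoyl on a saturated chain carbon, four bonds along the chain from an aromatic nitrogen). How the core of compound 1 differs from the core of compound 2 is not broken down here.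

Compound 4 `Nc1nc2cc(-c3nn(CCCCC(=O)NO)c4ncnc(N)c34)ccc2o1` carries the same kind of change, (2-(hydroxycarbamoyl)ethyl in place of hydroxycarbamoyl on a saturated chain carbon, two bonds along the chain from an aromatic nitrogen), but the place differs: two bonds along the chain from an aromatic nitrogen rather than four. Since compound 2 gives only a limit, the step of an at least 1.2-fold lower number from compound 2 to compound 4 (0.09 log units; that floor lies within the scatter) is expected to be at most of the size seen for compound 1 and compound 3. Compound 4 is therefore estimated at 120000 nM, between 30000 nM and 300000 nM.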

Compound 4, half-maximal inhibitory concentration: > 100000 nM
Compound 4: only a limit was reported (the forecaster's own chance of this, stated with the estimate: 55%); the middle value is on the limit's open side.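

Compound 2 and compound 4 are both reported only as limits in this assay, so the step between them cannot be read. The compounds shown leave open whether the longer chain changes the number on the core of compound 2.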